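Removing a nitrile from diaryl sulfide and sulfone anilines

The compounds below may be only part of what the source reports. "The series", "measured", "known", "first", "only" and "open" are said of these compounds alone.

Measured compounds:
- compound 1 `N#Cc1c(N)cccc1Sc1ccccc1`: 168000 nM
- compound 2 `N#Cc1cccc(Sc2cccc(N)c2C#N)c1`: 80000 nM
- compound 3 `N#Cc1c(N)cccc1S(=O)(=O)c1ccccc1`: > 5000 nM

All three were tested in a functional assay on MT4 cells (Homo sapiens) for cytotoxicity; on this read-out higher numbers stand for weaker inhibition and lower numbers for stronger inhibition. Compound 1 `N#Cc1c(N)cccc1Sc1ccccc1` gives 168000 nM, and compound 2 `N#Cc1cccc(Sc2cccc(N)c2C#N)c1` gives 80000 nM. Within the data shown here, the single change between them is hydrogen in place of cyano on an aromatic carbon, and this change gave a 2.1-fold higher number from compound 2 to compound 1 (0.32 log units; beyond the scatter). For compound 3 `N#Cc1c(N)cccc1S(=O)(=O)c1ccccc1`, this assay gives only a limit, > 5000 nM, which is the limit of > 5000 nM in this assay, at which 1 of the 3 values shown sits. The difference between the core of compound 3 and the core of compound 2 is not broken down here.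

Compound 4 `Nc1cccc(S(=O)(=O)c2ccccc2)c1` has not yet been measured in this assay. It differs from compound 3 by hydrogen in place of cyano on an aromatic carbon. Among the measured compounds shown here, this is the same kind of change as the one from compound 2 to compound 1, but not the same: in compound 4 the hydrogen enters ortho to a group of 9 heavy atoms and ortho to an amino group, whereas in compound 1 it enters meta to a large group.

Since the earlier removal of the cyano group gave only a modest shift, the step from compound 3 to compound 4 is expected to be of similar size, about a step that the limit leaves unreadable from compound 3 to compound 4. Because compound 3 itself is known only as a limit, > 5000 nM, compound 4 is likely to be reported as a limit as well. Compound 4 is estimated at 20000 nM, with a plausible range from 6000 nM to 150000 nM.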

Compound 4, half-maximal inhibitory concentration: > 50000 nM
Compound 4 was reported as a limit; the forecaster's own chance of this, stated with the estimate: 70%; middle value at least 2.5-fold (0.39 log units) away from the limit.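

Compound 3 and compound 4 are each known only as a limit in this assay, and the step between them cannot be read. What the compounds shown leave open is how far replacing the nitrile with hydrogen really moves the number in compound 3, and whether that shift comes close to the earlier change, which gave a 2.1-fold higher number from compound 2 to compound 1 (0.32 log units; beyond the scatter).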